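The source may report more compounds than this note shows. Statements on the series, on what has been measured and on what is new or still open speak of the compounds shown alone.

Working notes on a small series sharing one sulfonamide-linked core. Compound 1 `N#Cc1ccc(S(=O)(=O)N2C/C(=C\c3cccnc3)C(=O)/C(=C/c3ccccc3C(F)(F)F)C2)cc1` is tested in a functional assay on QGY-7703 cells (Homo sapiens) for cytotoxicity, read by MTT assay, with a stated time of 24 h (on this read-out lower numbers stand for stronger inhibition and higher numbers for weaker inhibition), where compound 1 gives 6150 nM. Compound 2 `CC(=O)Nc1ccc(S(=O)(=O)N2C/C(=C\c3cccnc3)C(=O)/C(=C/c3ccccc3C(F)(F)F)C2)cc1` differs from compound 1 only by acetamido in place of cyano on an aromatic carbon; in this assay compound 2 gives 5380 nM, and the step is a 1.1-fold lower number from compound 1 to compound 2 (0.06 log units; within the scatter). Compound 3 `N#Cc1ccc(S(=O)(=O)N2C/C(=C\c3ccncc3)C(=O)/C(=C/c3ccccc3C(F)(F)F)C2)cc1` carries a different core: the difference from compound 1 is pyridin-4-yl in place of pyridin-3-yl on a double-bonded chain carbon bound to a double-bonded ring carbon. In this assay compound 3 gives 6290 nM, with the step of a 1.0-fold higher number from compound 1 to compound 3 (0.01 log units; within the scatter). All three numbers sit within the usual scatter of one another, so no ordering among them is claimed.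

Compound 4 `CC(=O)Nc1ccc(S(=O)(=O)N2C/C(=C\c3ccncc3)C(=O)/C(=C/c3ccccc3C(F)(F)F)C2)cc1` is not yet measured. It differs from compound 3 by acetamido in place of cyano on an aromatic carbon, which is the same change as made from compound 1 to compound 2, at a place described in identical words, now on the core of compound 3. Since the earlier step was within the scatter, the step from compound 3 to compound 4 is expected to be small as well, estimated as a 1.1-fold lower number from compound 3 to compound 4 (0.05 log units; within the scatter). In this assay compound 4 is accordingly expected near 5600 nM, with a range estimated from 3300 nM to 9500 nM.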

Compound 4, half-maximal inhibitory concentration: 5560 nM
Compound 4: the middle estimate sits 1.0-fold (0.00 log units) above what was measured; low and high end bracket the measured number.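

In this assay, acetamido in place of cyano on an aromatic carbon gives a 1.1-fold lower number from compound 3 to compound 4 (0.05 log units; within the scatter), and this step reads the same on both cores: the same change on two cores in this assay, a 1.1-fold lower number (0.06 log units; within the scatter) from compound 1 to compound 2 and a 1.1-fold lower number (0.05 log units; within the scatter) from compound 3 to compound 4, 1.0-fold (0.00 log units) apart, within the scatter of two such steps

Pyridin-4-yl in place of pyridin-3-yl gives a 1.0-fold higher number from compound 2 to compound 4 (0.01 log units; within the scatter), and this step also reads the same on both cores: the same change on two cores in this assay, a 1.0-fold higher number (0.01 log units; within the scatter) from compound 1 to compound 3 and a 1.0-fold higher number (0.01 log units; within the scatter) from compound 2 to compound 4, 1.0-fold (0.00 log units) apart, within the scatter of two such steps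

Going by these compounds alone, both changes therefore carry between these cores without a visible difference, but every step lies within the scatter, so this shows only that neither change moved the number on either core, not that a change with a clear effect would carry over in the same way.

The compounds shown leave open whether another group in place of cyano, such as an amine or a carboxylic acid, would shift the number at all. They also leave open whether a methoxy group in place of trifluoromethyl would do so, and whether any such shift would carry from one core to the other.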